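A few compounds are considered here, and "the series" means these few. Any claim that something is new, unique, unknown or untested is made for them only; others in the source may bear on it.

Working notes on the series.

Compound 1 `O=C(CN(c1ncnc2c1ncn2C1CCCCO1)C1CC1)N[C@@H](CCC(=O)OCc1ccccc1)C(=O)OCc1ccccc1` is the reference point. In a functional assay on the whole organism (Tail, strain ICR) with Mus musculus as the target, in the tail flick test, with a stated time of 90 min, at a dose of 25 umol/kg by the oral route (a lower number here means a weaker effect, a higher number a stronger effect of the compound at the dose given), compound 1 gives 25.2%. Among the measured compounds shown here, the only other measured member is compound 2 `O=C(OCc1ccccc1)[C@@H]1CCCN1C(=O)CN(c1ncnc2c1ncn2C1CCCCO1)C1CC1`, which in this assay gives 23.3%; the gap between compound 2 and compound 1 lies within the usual scatter, so the two are read as one level of effect and neither is set above the other. For the measured compounds named here, no step between two measured compounds that differ in one place is available, so the series so far gives no direction for any change.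

Compound 3 `N=C(N)NCCC[C@H](NC(=O)CN(c1ncnc2c1ncn2C1CCCCO1)C1CC1)C(=O)OCc1ccccc1` is not yet measured. It differs from compound 1 as follows: a group of 5 heavy atoms (2 carbon, 3 nitrogen; no ring) in place of a group of 10 heavy atoms (8 carbon, 2 oxygen; one six-membered aromatic ring of carbon only), on a saturated chain carbon, three bonds along the chain from an amide-type nitrogen and a carbonyl carbon. Going by the values given here, nothing among the measured compounds tells how such an exchange acts, and the single level seen for compound 1 and compound 2 is the only anchor. The step expected in this assay is therefore small, a number 5.2 percentage points lower from compound 1 to compound 3 (within the scatter), not beyond the scatter and with a slight lean downward. For compound 3 the expected value in this assay is 20%, with a range from 5% to 38%.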

Compound 3, a percentage reported as activity, at one dose (the size of the read-out at that dose, not a potency): 61.6%
Estimate against measurement, compound 3: 41.6 percentage points below, and the stated range ends below it.
By their numbers in this assay, from the lowest: compounds 2 and 1 (each within the scatter of the next); then compound 3.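

In this assay, among the compounds shown here, putting the group of 5 heavy atoms (2 carbon, 3 nitrogen; no ring) in place of benzyloxycarbonyl on the saturated chain carbon, three bonds along the chain from an amide-type nitrogen and a carbonyl carbon, gives a number 36.4 percentage points higher from compound 1 to compound 3 (beyond the scatter), the only step so far and the one sign that the read-out responds to a change at this place. The exchange removes the one six-membered aromatic ring of carbon only and also goes from 0 to 3 hydrogen-bond donors, so this single step cannot separate the loss of the ring from the gain in donors. No measurement at hand bears on what lies behind the step.

Open, going by these compounds, is whether the step needs the whole entering group, or whether a plain primary amine or a carboxylic acid on the same chain carbon would give a similar level of effect, and whether a shorter or longer chain carrying the same group would keep it. The read-out also comes from one dose at one stated time, so it leaves open how the effect of compound 3 varies with dose or time.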